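Swapping the chain-end group: from compound 2 to compound 4

The compounds below may be only part of what the source reports. "The series", "measured", "known", "first", "only" and "open" are said of these compounds alone.

Measured compounds:
Compound 1, `CC/N=C(\S)NCCCCCn1nc(-c2ccccc2)ccc1=O`, gives 66.4% in a functional assay on the whole organism with Rattus norvegicus as the target, at a dose of 100 mg/kg; on this read-out lower numbers stand for less inhibition and higher numbers for more inhibition at the one dose given (going by the name of the read-out).
Compound 2, `CC/N=C(/NC#N)NCCCn1nc(-c2ccccc2)ccc1=O`, gives 62.9% in this assay.
Compound 3, `CC/N=C(/NC#N)NCCCn1nc(C)ccc1=O`, gives 34.5% in this assay.

Compound 2 stands second highest of the three numbers in this assay; its nearest neighbour is compound 1, with a number 3.5 percentage points lower from compound 1 to compound 2 (within the scatter), and its furthest is compound 3, with a number 28.4 percentage points lower from compound 2 to compound 3 (beyond the scatter).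

Compound 4, `CC/N=C(\S)NCCCn1nc(-c2ccccc2)ccc1=O`, has not been measured. It differs from compound 2 in this way: a group of 5 heavy atoms (3 carbon, 1 nitrogen, 1 sulfur; no ring) in place of a group of 7 heavy atoms (4 carbon, 3 nitrogen; no ring), on an amine nitrogen.

Going by the values given here, of the measured steps, only the one from compound 1 to compound 2 bears on this change, since it also exchanges the thiourea end against the cyanoguanidine end, though together with a change in chain length; that step was a number 3.5 percentage points lower from compound 1 to compound 2 (within the scatter). Compound 3 tells nothing about the end group. In this assay the step to compound 4 is therefore expected to stay within the scatter, a number 1.1 percentage points higher from compound 2 to compound 4 (within the scatter). Compound 4 is estimated at 64%, in the range 50% to 78%.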

Compound 4, a percentage reported as inhibition, in the whole organism at one dose (the size of the read-out at that dose, not a potency): 39%
For compound 4 the middle estimate is 25 percentage points above the measured one, outside the stated range (below it).
By their numbers in this assay, from the lowest: compounds 3 and 4 (each within the scatter of the next); then compounds 2 and 1 (each within the scatter of the next).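

On the shorter chain the end group matters in this assay: with the thiourea end in place of the cyanoguanidine end, the result is a number 23.9 percentage points lower from compound 2 to compound 4 (beyond the scatter). Chain length matters as well when the thiourea end is kept, with a number 27.4 percentage points lower from compound 1 to compound 4 (beyond the scatter), so the small step between compound 1 and compound 2, where both features change at once, had hidden two separate dependencies. Nothing available accounts for either step.

From the compounds shown here alone, it remains open whether the cyanoguanidine end on the longer chain of compound 1 would stand above compound 2 or level with it, and so whether the chain effect depends on the end group. Going by these compounds, how a urea or a plain amine at the chain end, or a chain of intermediate length, would compare also stays unknown.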